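The compounds below may be only part of what the source reports. "The series", "measured", "known", "first", "only" and "open" are said of these compounds alone.

Compound 3 `O=C(Nc1ccc(F)cc1)c1c(NO)cc(-c2ccccc2)oc1=O` carries a 4-fluorophenyl on its amide nitrogen and an unsubstituted phenyl on the shared core. In an ADME assay on Huh-7 cells (Homo sapiens) for cytotoxicity, read by a luciferase reporter and WST assay, with a stated time of 3 days (on this read-out higher numbers stand for lower toxicity in this test and lower numbers for higher toxicity in this test), compound 3 gives only > 20000 nM, which is a limit of the test and not a number, as set out in the limit of > 20000 nM in this assay, at which 1 of the 3 values shown sits. For the measured compounds named here, compound 1 `O=C(Nc1ccccc1)c1c(NO)cc(-c2ccc(F)cc2)oc1=O` gives 10300 nM in this assay, and compound 2 `O=C(Nc1ccccc1)c1c(NO)cc(-c2ccc(Cl)cc2)oc1=O` gives 11000 nM; the step of a 1.1-fold higher number from compound 1 to compound 2 (0.03 log units; within the scatter) is the only measured step, and it changes the aryl on the core, not the amide side. Going by the values given here, compound 4 `Cc1ccccc1NC(=O)c1c(NO)cc(-c2ccccc2)oc1=O` differs from compound 3 by 2-methylphenyl in place of 4-fluorophenyl on an amide-type nitrogen, a change at the amide nitrogen for which no measured step exists, so the step from compound 1 to compound 2 can only show that a small change on an aromatic ring left this assay unmoved. On that basis compound 4 is expected to stay near the limit, with a number no higher from compound 3 to compound 4 (the limit leaves the size open) as the estimated step. The estimate for compound 4 in this assay is 20000 nM, within 8000 nM to 40000 nM.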

Compound 4, half-maximal cytotoxic concentration: > 20000 nM
Compound 4 gave a limit, no number; the forecaster's own chance of this, stated with the estimate: 50%; the middle value lies on the limit itself.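

Compound 3 and compound 4 both give a limit of the test and not a number, so no step can be read between them: the limit of > 20000 nM in this assay, at which 2 of the 4 values shown sit.

The compounds shown leave open whether any change on the amide nitrogen moves the read-out in this assay.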